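This account rests on a few compounds, and the source may have more. Where it says the series, first, only, none or still open, it means among the compounds named here.

In an assay on cells for inhibition of HSP60/HSP10 (Homo sapiens), with a stated time of 60 min (a higher number here means a weaker inhibitor, a lower number a stronger inhibitor), compound 1 `O=S(=O)(Nc1ccc(-c2nc3ccccc3o2)cc1)c1ccccc1C(F)(F)F` gives 74000 nM. Among the measured compounds shown here, it is the only compound of the three for which a number is reported. Compound 2 `O=S(=O)(Nc1ccc2oc(-c3ccccc3)nc2c1)c1cccc(C(F)(F)F)c1` returns only a limit, > 100000 nM, in this assay. Compound 3 `C=Cc1ccc(S(=O)(=O)Nc2ccc3oc(-c4ccccc4)nc3c2)cc1` likewise returns only a limit, > 100000 nM, in this assay. The two remaining values therefore sit at the limit of > 100000 nM in this assay, at which 2 of the 3 values shown sit, so compound 1 alone offers a number from which to set out.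

Compound 4 `O=S(=O)(Nc1ccc(-c2nc3ccccc3o2)cc1)c1ccccc1Cl` is the next compound. It differs from compound 1 in one place: chloro in place of trifluoromethyl on an aromatic carbon. For the measured compounds named here, no measured pair among the three compounds shows what this exchange does in this assay, so the expectation rests on compound 1 alone. The author expects a step of a 1.1-fold lower number from compound 1 to compound 4 (0.02 log units; within the scatter), which stays within the usual scatter of the measurement. Compound 4 is accordingly estimated to give 70000 nM in this assay, with a likely range from 25000 nM to 200000 nM.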

Compound 4, half-maximal inhibitory concentration: > 100000 nM
Compound 4: only a limit was reported; the forecaster's own chance of this, stated with the estimate: 30%; at least 1.4-fold (0.15 log units) between middle value and limit.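

Among the compounds shown here, the exchange of trifluoromethyl for chloro on this aromatic carbon, ortho to a large group, is the first single-place change that can be read in this assay, and it gives an at least 1.3-fold higher number from compound 1 to compound 4 (0.13 log units; that floor lies within the scatter). That step is only a floor, since compound 4 carries a limit and not a number, so it shows that chloro does not keep a measurable value here but not that it causes a real loss. Compound 1 therefore remains the only compound with a number, and the values now gather at one point: the limit of > 100000 nM in this assay, at which 3 of the 4 values shown sit.

As far as these compounds go, how far past the limit compound 4 lies stays open, and with it whether chloro costs anything beyond the scatter. Also open, from the compounds shown here alone, is whether another group at this place, such as an amine, a carboxylic acid or plain hydrogen, would give a lower number than compound 1.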